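The source may hold more compounds than are shown below. What is called first, only, known or untested is meant among the compounds shown, and "the series" means these compounds.

Measured in a functional assay on HEK293 cells for positive allosteric modulation of metabotropic glutamate receptor 5 (Rattus norvegicus), read by fluorescence and calcium flux; on this read-out lower numbers stand for an effect already at smaller amounts and higher numbers for an effect only at larger amounts of compound:

Compound 1 `CS(=O)(=O)N1c2ccccc2CCC1C(=O)Nc1cccc(Cl)c1`: 1000 nM
Compound 2 `CCS(=O)(=O)N1c2ccccc2CC[C@H]1C(=O)Nc1cccc(Cl)c1`: 2500 nM
Compound 3 `O=C(Nc1cccc(Cl)c1)[C@@H]1CCc2ccccc2N1S(=O)(=O)c1ccccc1F`: 6700 nM

Of these three, compound 1 has the lowest number in this assay; compound 2 is nearest to it and compound 3 furthest away, both gaps beyond the scatter. Compound 4 `Cn1cnc(S(=O)(=O)N2c3ccccc3CCC2C(=O)Nc2cccc(Cl)c2)c1` is not yet measured. It differs from compound 1 in one place: 1-methyl-1H-imidazol-4-yl in place of methyl on a sulfonyl sulfur. Among the compounds with values here, the only measured step that bears on this change is the one on the same sulfonyl sulfur, where a larger aromatic group replaced a small alkyl: a 2.7-fold higher number from compound 2 to compound 3 (0.43 log units; beyond the scatter). Compounds 1 and 2 show that methyl to ethyl on that sulfur also moves the number upward. Together these suggest that enlarging the group on the sulfonyl sulfur raises the number in this assay, so a modest rise is expected for compound 4, with a five-membered aromatic ring now in place of methyl. The estimate for compound 4 is 2500 nM, between 1000 nM and 7000 nM, which is an expected step of a 2.5-fold higher number from compound 1 to compound 4 (0.40 log units; beyond the scatter).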

Compound 4, half-maximal effective concentration: > 10000 nM
Compound 4: a limit, no number; the forecaster's own chance of this, stated with the estimate: 5%; middle value at least 4.0-fold (0.60 log units) away from the limit.
By their numbers in this assay, from the lowest: compound 1; then compound 2; then compound 3. At a limit, above all of these: compound 4.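

In this assay, compound 4 gives a limit, not a number: the limit of > 10000 nM in this assay, at which 1 of the 4 values shown sits. The earlier step on this sulfonyl sulfur, a 2.7-fold higher number from compound 2 to compound 3 (0.43 log units; beyond the scatter), came from swapping ethyl for 2-fluorophenyl, while 1-methyl-1H-imidazol-4-yl in place of methyl gives an at least 10-fold higher number from compound 1 to compound 4 (1.00 log units; beyond the scatter). So this position does not accept every aromatic ring at a modest cost, and the real size of this step remains unknown, with only its lower bound printed.

The compounds shown cannot tell whether the ring itself, its two nitrogens or its methyl accounts for the change. A plain phenyl or an imidazol-4-yl without the methyl, set on the same sulfonyl sulfur of the core of compound 1, would help separate these possibilities.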